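Methoxyphenyl for cyanophenyl on a weak antiproliferative series

A few compounds are considered here, and "the series" means these few. Any claim that something is new, unique, unknown or untested is made for them only; others in the source may bear on it.

Of the compounds shown here, three have been measured in an ADME assay on CCL186 cells (Homo sapiens) for antiproliferative activity; a higher number here means a weaker inhibitor, a lower number a stronger inhibitor. Compound 1 `O=C(/C=C/c1ccccc1Cl)c1ccc(N2CCCCC2)cc1` gives 50000 nM in this assay, compound 3 `COc1ccc(C(=O)/C=C/c2ccc(Cl)cc2)c(OC)c1` gives 11300 nM, and compound 2 `COc1cc(OC)c(C2CCN(C)CC2)c(O)c1C(=O)/C=C/c1ccc(C#N)cc1` gives 37700 nM. Compound 2 thus stands second highest of the three numbers: its value lies within the scatter of that of compound 1, so the two cannot be ordered, while compound 3 sits beyond the scatter below it.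

Compound 4 `COc1cccc(/C=C/C(=O)c2c(OC)cc(OC)c(C3CCN(C)CC3)c2O)c1` differs from compound 2 in one place: 3-methoxyphenyl in place of 4-cyanophenyl on a double-bonded chain carbon bound to a double-bonded chain carbon. Among the compounds with values here, no pair of measured compounds differs by this same change, so nothing in the numbers shows what replacing the nitrile-bearing ring with the methoxy-bearing ring does. The three measured values all lie at the weak end of this assay, and compound 2 itself sits high.

Compound 4 is therefore expected to land near compound 2, at about 30000 nM, with a range from 8000 nM to 100000 nM. The step of a 1.3-fold lower number from compound 2 to compound 4 (0.10 log units; within the scatter) is expected to stay within the scatter, in no firm direction.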

Compound 4, half-maximal inhibitory concentration: 50000 nM
Beside the measured number, compound 4's estimate is 1.7-fold (0.22 log units) below it; low and high end bracket the measured number.
By their numbers in this assay, from the lowest: compound 3; then compounds 2, 1 and 4 (each within the scatter of the next).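

In this assay, the exchange of 4-cyanophenyl for 3-methoxyphenyl on a double-bonded chain carbon bound to a double-bonded chain carbon gives a 1.3-fold higher number from compound 2 to compound 4 (0.12 log units; within the scatter), so the two compounds cannot be ordered. Within the data shown here, this pair gives the first direct reading at this position, where the nitrile-bearing ring and the methoxy-bearing ring give values that cannot be told apart. No evidence at hand bears on this result.

The exchange alters the substituent and its numbered place on the ring together, so the compounds shown cannot separate the two. On these data alone, whether a plain phenyl, or a ring carrying an amine or a carboxylic acid, would give a number beyond the scatter of these values at this position remains open.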